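Half-life notes: methyl branch on the chain of compound 2

The compounds below may be only part of what the source reports. "The series", "measured", "known", "first", "only" and "open" are said of these compounds alone.

The shared core appears in compound 1 `COc1ccc(NC(=O)CNc2c([N+](=O)[O-])cc(C(=O)NCCO)cc2[N+](=O)[O-])cc1` and compound 2 `COc1ccc(NC(=O)CN(C)c2c([N+](=O)[O-])cc(C(=O)NCCO)cc2[N+](=O)[O-])cc1`. In an ADME assay for pharmacokinetics (on this read-out higher numbers stand for a longer-lived compound and lower numbers for a shorter-lived compound), compound 1 reports < 0.0167 h, which is the limit of < 0.0167 h in this assay, at which 1 of the 2 values shown sits, a limit rather than a number. In this assay, within the data shown here, compound 2 gives 0.12 h, the only full number in the set. Among the measured compounds shown here, the single measured step is an at least 7.1-fold higher number from compound 1 to compound 2 (0.85 log units; beyond the scatter). Compound 3 `COc1ccc(NC(=O)C(C)N(C)c2c([N+](=O)[O-])cc(C(=O)NCCO)cc2[N+](=O)[O-])cc1` differs from compound 2 by methyl in place of hydrogen on a saturated chain carbon bound to a carbonyl carbon and a nitrogen on an aromatic ring, a change of another kind, so that step bears on it only loosely. A modest step in this assay is expected, a 1.7-fold higher number from compound 2 to compound 3 (0.22 log units; within the scatter). For compound 3 the estimate is 0.2 h, between 0.08 h and 0.6 h.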

Compound 3, half-life: 0.2 h
Beside the measured number, compound 3's estimate shows no gap at the digits printed, within the range that was stated.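

On the saturated chain carbon bound to a carbonyl carbon and a nitrogen on an aromatic ring, methyl in place of hydrogen gives a 1.7-fold higher number from compound 2 to compound 3 (0.22 log units; within the scatter) in this assay, so this read-out does not separate the two compounds. This position thus accepts the added methyl with no change beyond the scatter, unlike the earlier change on the nitrogen, which gave an at least 7.1-fold higher number from compound 1 to compound 2 (0.85 log units; beyond the scatter). Nothing shown gives a reason for the result at the chain carbon.

On these data alone, whether an ethyl group or a cyclopropyl ring at this carbon would read the same stays open. So does the effect of this chain methyl with the hydrogen kept on the nitrogen.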